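Replacing furan-2-yl with propyl on a carbonyl carbon

The source may hold more compounds than are shown below. What is called first, only, known or untested is meant among the compounds shown, and "the series" means these compounds.

In a functional assay on U-87MG ATCC cells (Homo sapiens) for inhibition (a lower number here means a stronger inhibitor, a higher number a weaker inhibitor), three compounds sharing one core have been measured. Compound 2 (`COc1cc(/C=C/C(=O)c2cccc(NC(=O)c3ccco3)c2)ccc1O`), with furan-2-yl on a carbonyl carbon, gives 6.65 ug/mL and holds the lowest of the three numbers. Compound 1 (`COc1cc(/C=C/C(=O)c2cccc(NC(=O)c3c(Cl)cccc3Cl)c2)ccc1O`), with 2,6-dichlorophenyl at that place, gives 17.8 ug/mL while compound 3 (`COc1cc(/C=C/C(=O)c2cccc(NC(=O)c3ccc(Cl)c(Cl)c3)c2)ccc1O`), with 3,4-dichlorophenyl, gives 29.5 ug/mL in the same test. These two are not told apart: the data show a 1.7-fold higher number from compound 1 to compound 3 (0.22 log units; within the scatter) and no order is drawn from it.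

Compound 4 (`CCCC(=O)Nc1cccc(C(=O)/C=C/c2ccc(O)c(OC)c2)c1`) has not yet been measured. It carries propyl in place of furan-2-yl on a carbonyl carbon. Two measured steps at this same place bear on it: a 2.7-fold lower number from compound 1 to compound 2 (0.43 log units; beyond the scatter) and a 4.4-fold higher number from compound 2 to compound 3 (0.65 log units; beyond the scatter) are both modest and beyond the scatter. Both show compound 2 with the lower number, so the one direction seen on leaving furan-2-yl is upward. Neither step involves a group without a ring, however, so this guide is weak and a smaller rise is expected for propyl. The estimated step is a 1.8-fold higher number from compound 2 to compound 4 (0.26 log units; within the scatter) and it may not stand clear of repeat measurements. Compound 4 is thus estimated at 12 ug/mL (range 5 ug/mL to 28 ug/mL).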

Compound 4, half-maximal inhibitory concentration: 5.56 ug/mL
Compound 4: the middle estimate sits 2.2-fold (0.33 log units) above what was measured; low and high end bracket the measured number.
By their numbers in this assay, from the lowest: compounds 4 and 2 (each within the scatter of the next); then compounds 1 and 3 (each within the scatter of the next).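

In this assay, exchanging the ring for a chain at this place on the carbonyl carbon gives a 1.2-fold lower number from compound 2 to compound 4 (0.08 log units; within the scatter), so among these compounds a number at the level of compound 2 does not depend on an aromatic ring, since propyl has no ring at all. The same chain stands well apart from both dichlorophenyl groups, with a 5.3-fold lower number from compound 3 to compound 4 (0.72 log units; beyond the scatter) and a 3.2-fold lower number from compound 1 to compound 4 (0.51 log units; beyond the scatter), so the four compounds fall into two sets: compounds 2 and 4, which carry no chlorine, and compounds 1 and 3, which carry the dichlorophenyl groups, and the presence or absence of a ring alone does not separate these sets. No measurement at hand accounts for this division, and the data give no reason why propyl and furan-2-yl sit together.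

The compounds shown leave open whether it is the chlorine atoms or the larger six-membered ring that goes with the higher numbers, a question that an unsubstituted phenyl group at this place would address. They also leave open whether the level seen with propyl extends to a longer chain such as hexyl, or to a chain carrying an amine or a carboxylic acid.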